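Open-chain amino acid tail replacing the carboxypiperidine: compound 4

The source may report more compounds than this note shows. Statements on the series, on what has been measured and on what is new or still open speak of the compounds shown alone.

Compound 2 `COc1ccc(/C=C\c2cc(OC)c(OC)c(OC)c2)cc1OCc1ccc(CN2CCCC[C@H]2C(=O)O)cc1` carries a 2-carboxypiperidin-1-yl group on a saturated chain carbon bound to an aromatic carbon. In a functional assay on B16-F10 cells (Mus musculus) for antiproliferative activity, read by CCK-8 assay, with a stated time of 48 h (on this read-out lower numbers stand for stronger inhibition and higher numbers for weaker inhibition), compound 2 reaches only > 10000 nM, which is a limit of the method and not a number. The other acid, compound 1 `COc1ccc(/C=C\c2cc(OC)c(OC)c(OC)c2)cc1OCc1ccc(CN2CC(C(=O)O)C2)cc1`, stops at the same point. In this assay compound 1 gives > 10000 nM, again a limit. The step that the two limits leave unreadable from compound 1 to compound 2 is unreadable because both compounds sit at the limit of > 10000 nM in this assay, at which 2 of the 3 values shown sit. Only compound 3 `COc1ccc(/C=C\c2cc(OC)c(OC)c(OC)c2)cc1OCc1ccc(CN2CCCCC2C(=O)NCCN)cc1`, with the 2-((2-aminoethyl)carbamoyl)piperidin-1-yl group, returns a number: in this assay compound 3 gives 4600 nM. The steps of an at least 2.1-fold lower number from compound 1 to compound 3 (0.33 log units; beyond the scatter) and an at least 2.1-fold lower number from compound 2 to compound 3 (0.33 log units; beyond the scatter) show that exchanging the carboxylic acid for the aminoethyl amide is the only move among these three that produces a readable value.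

Compound 4 `COc1ccc(/C=C\c2cc(OC)c(OC)c(OC)c2)cc1OCc1ccc(CN[C@H](C(=O)O)[C@@H](C)O)cc1` is unmeasured. Its change from compound 2 is (1-carboxy-2-hydroxypropyl)amino in place of 2-carboxypiperidin-1-yl on a saturated chain carbon bound to an aromatic carbon. Compound 4 keeps a carboxylic acid, as do compound 1 and compound 2, both of which stop at the limit. Among the measured compounds shown here, no measured step covers the ring opening or the added hydroxyl. Compound 4 is therefore expected to stay close to the limit, and a step that the limit leaves unreadable from compound 2 to compound 4 is expected to be small. The estimate for compound 4 in this assay is 15000 nM, within 5000 nM to 50000 nM.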

Compound 4, half-maximal inhibitory concentration: 5400 nM
For compound 4 the middle estimate is 2.8-fold (0.44 log units) above the measured one, within the range that was stated.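

In this assay compound 4 is the only carboxylic acid among the compounds shown that returns a number, 5400 nM. Keeping a carboxylic acid on this saturated chain carbon therefore does not by itself leave a compound at the limit: the limit of > 10000 nM in this assay, at which 2 of the 4 values shown sit.

The gain over the two ring acids stays unsized, as the step of an at least 1.8-fold lower number from compound 2 to compound 4 (0.26 log units; that floor lies within the scatter) and the step of an at least 1.8-fold lower number from compound 1 to compound 4 (0.26 log units; that floor lies within the scatter) each rest on a limit. The step of a 1.2-fold higher number from compound 3 to compound 4 (0.07 log units; within the scatter) shows that the (1-carboxy-2-hydroxypropyl)amino group and the 2-((2-aminoethyl)carbamoyl)piperidin-1-yl group cannot be told apart in this assay, so a readable value at this place no longer belongs to the aminoethyl amide alone.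

Compound 4 differs from compound 2 by an opened ring and an added hydroxyl together, and the compounds shown do not say which of the two goes with the readable value. A (1-carboxyethyl)amino group, with the open chain and no hydroxyl, would separate the two changes, and a 3-hydroxy-2-carboxypiperidin-1-yl group would test the hydroxyl with the ring kept.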